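The compounds below may be only part of what the source reports. "The series", "measured", "known", "first", "only" and "open" are said of these compounds alone.

Compound 1 (`COc1ccc(CN(C(=O)Nc2ccc(F)c(Cl)c2)n2cnnc2)cc1OC`) is a urea in which a 3-chloro-4-fluorophenyl group sits on an amide-type nitrogen. In a functional assay on A549 cells (Homo sapiens) for cytotoxicity, read by MTT assay, with a stated time of 48 h (a lower number here means a stronger inhibitor, a higher number a weaker inhibitor), compound 1 gives 21000 nM. Among the measured compounds shown here, compound 2 (`COc1ccc(OC)c(CN(C(=O)Nc2ccc(C)cc2)n2cnnc2)c1`) carries a methylphenyl group in the corresponding place, and in this assay compound 2 gives 17400 nM, a number that lies within the usual scatter of the one for compound 1, so the two cannot be told apart. Compound 3 (`O=C(NC1CCCCC1)N(Cc1ccccn1)n1cnnc1`), with a cyclohexyl group on that nitrogen, reaches only a limit of the assay, > 50000 nM, and no number is known for it (the limit of > 50000 nM in this assay, at which 1 of the 3 values shown sits).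

Compound 4 (`CCc1ccc(NC(=O)N(Cc2ccc(OC)c(OC)c2)n2cnnc2)cc1`) differs from compound 1 in one place: 4-ethylphenyl in place of 3-chloro-4-fluorophenyl on an amide-type nitrogen. Compound 2 shows that a plain alkyl-substituted phenyl in this position gives a number close to that of compound 1, so little movement beyond the scatter is expected. The step from compound 1 to compound 4 is estimated at a 1.1-fold higher number from compound 1 to compound 4 (0.06 log units; within the scatter). For compound 4 the expected value in this assay is 24000 nM, within a range from 10000 nM to 55000 nM.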

Compound 4, half-maximal inhibitory concentration: 28400 nM
Compound 4: middle estimate off by 1.2-fold (0.07 log units), on the low side, and the stated range covers the measured number.
By their numbers in this assay, from the lowest: compounds 2, 1 and 4 (each within the scatter of the next). At a limit, above all of these: compound 3.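

Among the compounds shown here, this is the first change at this position that can be read with the rest of the molecule held fixed: in this assay, 4-ethylphenyl in place of 3-chloro-4-fluorophenyl on the amide-type nitrogen gives a 1.4-fold higher number from compound 1 to compound 4 (0.13 log units; within the scatter). The chlorine and fluorine can therefore give way to an all-carbon group with the same count of heavy atoms, and the number cannot be told apart from that of the halogenated ring. Nothing measured here accounts for how little the number moves.

From the compounds shown here alone, it remains open how an amine or a carboxylic acid on this phenyl ring would read, or a longer chain in place of the ethyl group. Going by these compounds, compound 3 differs from compound 1 in more than one place, so whether a cyclohexyl group on this nitrogen matters on its own also stays open.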